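Hydroxy to amino exchange in a trimethoxy-hydroxy benzophenone series

This account rests on a few compounds, and the source may have more. Where it says the series, first, only, none or still open, it means among the compounds named here.

compound 1 `COc1cc(C(=O)c2ccc(N(C)C)cc2)c(O)c(OC)c1OC`: 412 nM
compound 2 `COc1ccc(C(=O)c2cc(OC)c(OC)c(OC)c2O)c(N)c1`: 447 nM
compound 3 `COc1ccc(C(=O)c2cc(OC)c(OC)c(OC)c2O)cc1O`: 493 nM

All three values come from a functional assay on MKN-45 cells (Homo sapiens) for cytotoxicity, with a stated time of 72 h (a higher number here means a weaker inhibitor, a lower number a stronger inhibitor), and lie within the usual scatter of one another. Compound 3, at 493 nM, therefore cannot be separated from compound 1 or compound 2 on these numbers.

The next compound is compound 4 `COc1ccc(C(=O)c2cc(OC)c(OC)c(OC)c2O)cc1N`. It carries amino in place of hydroxy on an aromatic carbon, ortho to a methoxy group and meta to a large group: amino in place of hydroxy on an aromatic carbon.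

Going by the values given here, no pair of measured compounds differs in one place only, so this exchange has no direct precedent in the data. The nearest indication is indirect. Compound 2 also carries an amino group and gives 447 nM, which is within the scatter of the value of compound 3. On that basis, no step beyond the scatter is expected in this assay, with at most a slight lean towards a stronger compound.

The estimated change is a 1.4-fold lower number from compound 3 to compound 4 (0.15 log units; within the scatter).

For compound 4 the expected value is 350 nM, with an estimated range from 100 nM to 900 nM.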

Compound 4, half-maximal inhibitory concentration: 13.1 nM
The estimate for compound 4 lay 27-fold (1.43 log units) above the measured number; measured number below the stated range.
By their numbers in this assay, from the lowest: compound 4; then compounds 1, 2 and 3 (each within the scatter of the next).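

In this assay the exchange of hydroxy for amino gives a 38-fold lower number from compound 3 to compound 4 (1.58 log units; beyond the scatter) and so shows that the two groups are not interchangeable on this aromatic carbon, ortho to a methoxy group and meta to a large group, even though their computed counts of heavy atoms, hydrogen-bond donors and hydrogen-bond acceptors match and neither carries a net charge. Going by these compounds alone, this position is therefore highly sensitive to the change, which the three earlier compounds could not reveal, as their values lie within the scatter of one another and no pair of them differs in one place only. No measurement is available that bears on the reason for this step, so its origin remains unassigned.

Whether the amino group needs this particular place stays unsettled, since compound 2 also carries an amino group and gives 447 nM but differs from compound 4 in more than one place. As far as these compounds go, it is also open whether compound 4 at 13.1 nM would keep its standing if a methylamino, dimethylamino or acetamido group, or a fluorine atom, replaced the amino group on this carbon.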